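The compounds below may be only part of what the source reports. "The series", "measured", "known", "first", "only" and "open" are said of these compounds alone.

Two compounds sharing a core differ at a single aromatic carbon: compound 1 `COc1ccc(C2=NN(C3=NC(=O)/C(=C4\C(=O)Nc5ccc(Br)cc54)S3)C(c3ccc(Cl)cc3)C2)cc1` and compound 2 `COc1ccc(C2=NN(C3=NC(=O)/C(=C4\C(=O)Nc5ccc(Cl)cc54)S3)C(c3ccc(Cl)cc3)C2)cc1`. In a functional assay on cells (Cancer cell lines, Homo sapiens) for cytotoxicity, read by sulforhodamine B assay, with a stated time of 48 h (a lower number here means a stronger inhibitor of growth, a higher number a weaker inhibitor of growth), compound 1 gives 7440 nM, while compound 2 gives 450 nM. The change between them is chloro in place of bromo on an aromatic carbon and it made a large step, a 17-fold lower number from compound 1 to compound 2 (1.22 log units; beyond the scatter). Compound 3 `CN(C)c1ccc(C2CC(c3ccccc3)=NN2C2=NC(=O)/C(=C3\C(=O)Nc4ccc(Br)cc43)S2)cc1` carries a different core; how it differs from compound 1 is not broken down here. In this assay compound 3 gives 420 nM, within the scatter of compound 2 and well apart from compound 1. Compound 4 `CN(C)c1ccc(C2CC(c3ccccc3)=NN2C2=NC(=O)/C(=C3\C(=O)Nc4ccc(Cl)cc43)S2)cc1` applies the same change to compound 3, (chloro in place of bromo on an aromatic carbon), at a place described identically. For the measured compounds named here, only one earlier instance of this change exists, so its transfer to the second core is uncertain; an expected step of a 2.8-fold lower number from compound 3 to compound 4 (0.45 log units; beyond the scatter) rests on compound 1 to compound 2 tempered for a single precedent. Compound 4 is estimated at 150 nM, between 40 nM and 600 nM.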

Compound 4, concentration for total growth inhibition: 410 nM
Beside the measured number, compound 4's estimate is 2.7-fold (0.44 log units) below it; the range from low to high includes it.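

In this assay, chloro in place of bromo on an aromatic carbon gives a 1.0-fold lower number from compound 3 to compound 4 (0.01 log units; within the scatter), so the large step on the core of compound 1 does not recur on the core of compound 3. Set side by side, the two steps disagree: the same change on two cores in this assay, a 17-fold lower number (1.22 log units; beyond the scatter) from compound 1 to compound 2 and a 1.0-fold lower number (0.01 log units; within the scatter) from compound 3 to compound 4, 16-fold (1.21 log units) apart, beyond the scatter of two such steps. The outcome of this change therefore depends on the core in these two pairs, but the pairs do not show which difference between the cores matters or how the change would behave on a third core.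

Open, as far as these compounds go, is how fluoro or a nitrile would compare with chloro and bromo at that aromatic carbon on each core. Also open, from the compounds shown here alone, is whether a morpholine or a carboxylic acid in place of the dimethylamino group would alter the step on the core of compound 3.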